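The compounds below may be only part of what the source reports. "The series", "measured", "known", "first", "only" and "open" are said of these compounds alone.

Working notes on the series. In a functional assay on MCF7 cells (Homo sapiens) for inhibition, read by sulforhodamine B assay, with a stated time of 72 h (a lower number here means a stronger inhibitor of growth, a higher number a weaker inhibitor of growth), compound 1 `O=C(O)/C=C/c1ccncc1-c1ccc2ccccc2c1` gives > 10000 nM, which is a limit and not a number. Compound 2 `COC1CN(C(=O)/C=C/c2ccncc2-c2ccc3ccccc3c2)C1` gives > 10000 nM, also a limit. Compound 1 therefore has no numerical standing in the series, and the evidence so far is the limit of > 10000 nM in this assay, at which 2 of the 2 values shown sit.

Compound 3 `O=C(O)CCc1ccncc1-c1ccc2ccccc2c1` differs from compound 1 in a single place: 2-carboxyethyl in place of 2-carboxyethenyl on an aromatic carbon. In words, 2-carboxyethyl stands in place of 2-carboxyethenyl on an aromatic carbon, with the rest of the core unchanged.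

Among the measured compounds shown here, the only measured step is a step that the two limits leave unreadable from compound 1 to compound 2, with 3-methoxyazetidin-1-yl in place of hydroxy on a carbonyl carbon. It lies at a different point of the side chain and has no readable size, so it gives no guide to the size or direction of the new change. No step beyond the scatter is therefore expected in this assay, and compound 3 will most likely return a limit again. The expected step is a step that the limit leaves unreadable from compound 1 to compound 3. For compound 3 the estimated value is 15000 nM, with an expected range of 6000 nM to 40000 nM.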

Compound 3, concentration for 50% growth inhibition: > 10000 nM
Compound 3: only a limit was reported; the forecaster's own chance of this, stated with the estimate: 85%; the middle value does not contradict the limit.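

In this assay compound 3 gives > 10000 nM, which is a limit and not a number. The step from compound 1 to compound 3 therefore cannot be read, and neither can the step from compound 1 to compound 2: the limit of > 10000 nM in this assay, at which 3 of the 3 values shown sit. The compounds shown leave open which change to the shared core, if any, would give a measurable value.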